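A Nitro Swap on the Sulfonyl Group

The source may hold more compounds than are shown below. What is called first, only, known or untested is meant among the compounds shown, and "the series" means these compounds.

Compound 1 `COc1ccc(Cc2nnc(NC(=O)/C(C#N)=C/c3ccccc3OS(=O)(=O)c3ccccc3[N+](=O)[O-])s2)cc1` gives 18%
Compound 2 `COc1ccc(S(=O)(=O)Oc2ccccc2/C=C(\C#N)C(=O)Nc2nnc(Cc3cccc4ccccc34)s2)cc1` gives 29%

In an ADME assay on HEK-293T cells (Homo sapiens) for inhibition, read by CCK-8 assay, with a stated time of 48 h, tested at 20 uM (on this read-out lower numbers stand for less inhibition of growth and higher numbers for more inhibition of growth at the one concentration tested), compound 2 gives 29% and stands highest of the two measured compounds, with a gap to compound 1 that lies beyond the usual scatter. Compound 3 `N#C/C(=C\c1ccccc1OS(=O)(=O)c1ccccc1[N+](=O)[O-])C(=O)Nc1nnc(Cc2cccc3ccccc23)s1` has yet to be measured. It departs from compound 2 in one place: 2-nitrophenyl in place of 4-methoxyphenyl on a sulfonyl sulfur is the whole change, with 2-nitrophenyl in place of 4-methoxyphenyl on a sulfonyl sulfur. Among the compounds with values here, no two measured compounds differ in this place alone, so the data hold no direct measure of this change. Within the data shown here, the only hint is that compound 1 carries the same 2-nitrophenyl group and gives 18% in this assay while also differing from compound 3 elsewhere. That hint is weak, so only a slight fall is expected. The estimated change, a number 5 percentage points lower from compound 2 to compound 3 (within the scatter) in this assay, would stay within the usual scatter. The expected value for compound 3 is 24% with an estimated range from 8% to 42% on this read-out.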

Compound 3, percent growth inhibition at one concentration: "not toxic" (no number reported)
The entry for compound 3 holds no number, so the estimate cannot be set against anything.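

In this assay, within the data shown here, compound 3 is entered as "not toxic" (no number reported), so no step from compound 2 to compound 3 can be read. Nothing on hand offers an explanation for this entry. From the compounds shown here alone, how far 2-nitrophenyl in place of 4-methoxyphenyl on a sulfonyl sulfur shifts growth inhibition, taken alone, stays open.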